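Moving the methyl group of compound 2

The source may report more compounds than this note shows. Statements on the series, on what has been measured and on what is new or still open speak of the compounds shown alone.

Compound 1 `COc1ccc(OC)c(C(=O)/C=C/c2ccoc2)c1`: 18200 nM
Compound 2 `COc1ccc(OC)c(C(=O)/C=C/c2ccc(C)s2)c1`: 2600 nM

Among the measured compounds shown here, in a functional assay on MCF7 cells (Homo sapiens) for cytotoxicity, read by MTT assay (on this read-out higher numbers stand for weaker inhibition and lower numbers for stronger inhibition), compound 2 has the lower of the two numbers measured so far, which makes it the stronger inhibitor of the pair. Compound 3 `COc1ccc(OC)c(C(=O)/C=C/c2sccc2C)c1` is still unmeasured. It has the same atoms as compound 2, joined differently: 3-methylthiophen-2-yl in place of 5-methylthiophen-2-yl on a double-bonded chain carbon bound to a double-bonded chain carbon. For the measured compounds named here, only one measured step bears on this, and only loosely: a 7.0-fold lower number from compound 1 to compound 2 (0.85 log units; beyond the scatter). That step exchanged one ring for another, whereas here the ring type stays and only the methyl group moves. Going by the values given here, no measured pair tests such a move, so the data give no firm direction. A smaller step is expected in this assay, probably none beyond the scatter. The expected step is a 1.2-fold higher number from compound 2 to compound 3 (0.06 log units; within the scatter). For compound 3 the estimated value is 3000 nM, with an expected range from 1000 nM to 9000 nM.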

Compound 3, half-maximal inhibitory concentration: 7600 nM
Compound 3: middle estimate off by 2.5-fold (0.40 log units), on the low side; measured number inside the range.
By their numbers in this assay, from the lowest: compound 2; then compound 3; then compound 1.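

Where the methyl group sits on the ring matters in this assay: with the same atoms, 3-methylthiophen-2-yl in place of 5-methylthiophen-2-yl gives a 2.9-fold higher number from compound 2 to compound 3 (0.47 log units; beyond the scatter) and so gives back part of what the earlier ring exchange gained. The number still stays lower than with furan-3-yl, as the step of a 2.4-fold lower number from compound 1 to compound 3 (0.38 log units; beyond the scatter) shows, so all three compounds now fall in a clear order. Nothing measured here explains why moving the methyl group changes the number.

The compounds shown leave open how thiophen-2-yl without any methyl group would compare, and so whether the methyl group helps at one place or hurts at the other. Also open, going by these compounds, is whether a chlorine atom or an amine in place of the methyl group would follow the same order.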